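This account rests on a few compounds, and the source may have more. Where it says the series, first, only, none or still open, it means among the compounds named here.

In an ADME assay on HepG2 cells (Homo sapiens) for cytotoxicity, with a stated time of 72 h (a lower number here means that less compound is needed, a higher number that more compound is needed for the effect), compound 1 `Cc1cc(NC(=O)Nc2ccccc2OC(F)(F)F)c2ccccc2n1` reads > 25000 nM, which is a limit of the assay and not a number. Within the data shown here, the only true number so far comes from compound 2 `Cc1cc(NC(=O)Nc2ccc(Cl)c(Cl)c2)c2ccccc2n1`, which gives 17000 nM. Compound 3 `Cc1cc(NC(=O)Nc2ccccc2N)c2ccccc2n1` shares its core with compound 1 but carries amino in place of trifluoromethoxy on an aromatic carbon. Among the measured compounds shown here, no measured step shows what such a swap does, so only a small shift toward less compound needed is expected, and it may stay within the scatter: an at least 1.1-fold lower number from compound 1 to compound 3 (0.05 log units; that floor lies within the scatter). For compound 3 the estimated value is 22000 nM, with a range from 9000 nM to 50000 nM.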

Compound 3, half-maximal effective concentration: > 25000 nM
Compound 3: no number, only a limit; the forecaster's own chance of this, stated with the estimate: 50%; middle value at least 1.1-fold (0.05 log units) from the limit.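

Compound 1 and compound 3 both stop at a limit of the assay and not at a number, so no step can be read between them: the limit of > 25000 nM in this assay, at which 2 of the 3 values shown sit. On these data alone, whether amino and trifluoromethoxy give different values here, and by how much, stays open.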